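The source may report more compounds than this note shows. Statements on the series, on what has been measured and on what is new or still open speak of the compounds shown alone.

In an ADME assay on HEK-293T cells (Homo sapiens) for cytotoxicity, read by luminescence, with a stated time of 24 h (on this read-out higher numbers stand for lower toxicity in this test and lower numbers for higher toxicity in this test), compound 3 `CCCNC(=O)C1CCN(C(=O)c2cc3sc(C)cc3n2Cc2ccc(OC)cc2)CC1` is the only one of the three measured compounds to give a definite number, 36300 nM. Compound 1 `CCCNC(=O)C1CCN(C(=O)c2cc3sc(C(=O)c4ccccc4)cc3n2Cc2ccc(OC)cc2)CC1` reaches only a limit of the test, > 100000 nM. Compound 2 `CCCNCc1cc2c(cc(C(=O)N3CCC(C(=O)NCCC)CC3)n2Cc2ccc(OC)cc2)s1` likewise stops at a limit, > 100000 nM. Both neighbours of compound 3 thus sit at the limit of > 100000 nM in this assay, at which 2 of the 3 values shown sit. Compound 4 `CCCNC(=O)C1CCN(C(=O)c2cc3sc(-c4ccccc4)cc3n2Cc2ccc(OC)cc2)CC1` differs from compound 3 by phenyl in place of methyl on an aromatic carbon. Among the measured compounds shown here, the steps that bear on this are an at least 2.7-fold lower number from compound 1 to compound 3 (0.44 log units; beyond the scatter) and an at least 2.7-fold lower number from compound 2 to compound 3 (0.44 log units; beyond the scatter), both of which ran toward compound 3 and its lower number as a larger group gave way to a smaller one. Putting a larger group back is therefore expected to raise the number by about a 2.8-fold higher number from compound 3 to compound 4 (0.44 log units; beyond the scatter) in this assay. Compound 4 is estimated at 100000 nM, within 30000 nM to 300000 nM, with a fair chance that only a limit is reported.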

Compound 4, half-maximal cytotoxic concentration: > 100000 nM
Compound 4 was reported as a limit; the forecaster's own chance of this, stated with the estimate: 55%; the middle value sits exactly at the limit.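

On an aromatic carbon next to the ring sulfur, phenyl in place of methyl gives an at least 2.7-fold higher number from compound 3 to compound 4 (0.44 log units; beyond the scatter) in this assay, so a plain aromatic ring, with neither the carbonyl of benzoyl nor the amine of (propylamino)methyl, is enough for this change. Among the compounds shown here, only methyl gives a definite number so far, and the other three groups stop at the same limit: the limit of > 100000 nM in this assay, at which 3 of the 4 values shown sit. The steps among compound 1, compound 2 and compound 4 join two limits and cannot be read.

On these data alone, whether these three compounds differ at all stays open. Also open, as far as these compounds go, is where hydrogen, ethyl or a phenyl carrying a carboxylic acid would fall at this position.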